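Ester chain length and the step to compound 4

The source may hold more compounds than are shown below. What is called first, only, known or untested is meant among the compounds shown, and "the series" means these compounds.

Values in a functional assay on the whole organism with Scenedesmus acutus as the target, with a stated time of 20 h (on this read-out lower numbers stand for stronger inhibition and higher numbers for weaker inhibition), so far, by compound:
- compound 1 `CCCOC(=O)c1cc(N2C(=O)C3=C(CCCC3)C2=O)ccc1Cl` gives 661 nM on the propyl ester
- compound 2 `CCCCOC(=O)c1cc(N2C(=O)C3=C(CCCC3)C2=O)ccc1Cl` gives 7760 nM on the butyl ester
- compound 3 `CC(C)(C)OC(=O)c1cc(N2C(=O)C3=C(CCCC3)C2=O)ccc1Cl` gives > 100000 nM on the tert-butyl ester, which is a limit

Compound 3 has no number on this read-out, only the limit of > 100000 nM as reported. The next structure, compound 4 `CCCCCCCCOC(=O)c1cc(N2C(=O)C3=C(CCCC3)C2=O)ccc1Cl`, carries octyl in place of tert-butyl on an oxygen next to a carbonyl group on the shared core.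

Going by the values given here, three measured steps bear on this change. Going from propyl to butyl gave a 12-fold higher number from compound 1 to compound 2 (1.07 log units; beyond the scatter) and is the only step between straight chains. The tert-butyl steps, an at least 150-fold higher number from compound 1 to compound 3 (2.17 log units; beyond the scatter) and an at least 12-fold higher number from compound 2 to compound 3 (1.11 log units; beyond the scatter), place the branched ester beyond both straight chains, though their sizes are bounded only by the limit.

Octyl is a straight chain, but no chain longer than butyl has been measured. Extending the single propyl to butyl step suggests weaker inhibition than in compound 2 at 7760 nM. Compound 4 need not reach the limit seen for compound 3. In this assay a moderate move towards a lower number is therefore expected, and the estimated step is an at least 3.3-fold lower number from compound 3 to compound 4 (0.52 log units; beyond the scatter) as a result. It may vanish if the limit is reached again.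

For compound 4 the expected value is 30000 nM with an estimated range of 5000 nM to 100000 nM as its bounds.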

Compound 4, half-maximal inhibitory concentration: > 100000 nM
Compound 4: only a limit was reported (the forecaster's own chance of this, stated with the estimate: 35%); middle value at least 3.3-fold (0.52 log units) away from the limit.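

In this assay compound 4 gives only a limit, > 100000 nM, so the octyl ester has no number on this read-out. Even so, the straight-chain esters now run in one direction from propyl through butyl to octyl, with an at least 12-fold higher number from compound 2 to compound 4 (1.11 log units; beyond the scatter) and an at least 150-fold higher number from compound 1 to compound 4 (2.17 log units; beyond the scatter), so a straight chain, and not only the branched tert-butyl, can leave the measurable range. The step between the tert-butyl and octyl esters cannot be read, and two differently shaped esters now share the same ceiling: the limit of > 100000 nM in this assay, at which 2 of the 4 values shown sit.

Still open, going by these compounds, is where between butyl and octyl the inhibition is lost, which a pentyl or hexyl ester on the same core would help to place. Also open, on these data alone, is whether an ethyl or methyl ester, or the free carboxylic acid, would give a lower number than compound 1 at 661 nM, since propyl is so far the shortest chain and the position has no known optimum.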